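Homologating the sulfamide linker in a piperidinyl-pyrimidine series

The source may hold more compounds than are shown below. What is called first, only, known or untested is meant among the compounds shown, and "the series" means these compounds.

Measured compounds: compound 1 `NS(=O)(=O)NCC1CCN(c2cc(-c3ccc(Cl)cc3)ncn2)CC1` gives 25500 nM in a functional assay on MCF7 cells (Homo sapiens) for antiproliferative activity, read by sulforhodamine B assay, with a stated time of 48 h; a higher number here means a weaker inhibitor of growth, a lower number a stronger inhibitor of growth; compound 2 `COC(=O)c1ccc(-c2cc(N3CCC(CNS(N)(=O)=O)CC3)ncn2)cc1` gives 17700 nM; compound 3 `NS(=O)(=O)NCC1CCN(c2cc(-c3ccccc3Cl)ncn2)CC1` gives 62400 nM.

On these numbers compound 1 stands second highest of three, closest to compound 2 and furthest from compound 3. Compound 4 `NS(=O)(=O)NCCC1CCN(c2cc(-c3ccc(Cl)cc3)ncn2)CC1` differs from compound 1 by (sulfamoylamino)methyl in place of sulfamoylamino on a saturated chain carbon bound to a saturated ring carbon. Neither measured step touches this chain: the aryl substituent swap gave a 1.4-fold lower number from compound 1 to compound 2 (0.16 log units; within the scatter), and the aryl isomer change gave a 2.4-fold higher number from compound 1 to compound 3 (0.39 log units; beyond the scatter). Both alter the aromatic end, leaving the linker untouched, so no direct guide exists. Compound 4 is therefore expected to sit close to compound 1, with a step of a 1.0-fold lower number from compound 1 to compound 4 (0.01 log units; within the scatter) anticipated within the scatter. The estimate for compound 4 is 25000 nM, ranging from 9000 nM to 65000 nM.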

Compound 4, concentration for 50% growth inhibition: 19700 nM
The estimate for compound 4 lay 1.3-fold (0.10 log units) above the measured number, and the stated range covers the measured number.
By their numbers in this assay, from the lowest: compounds 2, 4 and 1 (each within the scatter of the next); then compound 3.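

In this assay, the change at the chain itself, (sulfamoylamino)methyl in place of sulfamoylamino, gives a 1.3-fold lower number from compound 1 to compound 4 (0.11 log units; within the scatter) and so leaves the number within the scatter. Unlike the earlier steps, which changed only the aromatic end, this one shows that the linker in the compound 1 series can carry the 2-(sulfamoylamino)ethyl chain without a step beyond the scatter. Nothing given here explains this result.

On these data alone, whether a longer chain would also stay within the scatter remains open. So does the outcome of an amine or a carboxylic acid in place of the sulfamoylamino group.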